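The compounds below may be only part of what the source reports. "The series", "measured", "known", "first", "only" and "open" are said of these compounds alone.

Working notes on the series. Among the measured compounds shown here, compound 1 `Cc1cc(-c2nc3sc(C)cn3c2/C=N/NC(=N)N)c(C)s1` and compound 2 `Cc1cn2c(/C=N/Nc3ccccn3)c(-c3ccc(Cl)c([N+](=O)[O-])c3)nc2s1` are the two compounds with numbers so far. In a functional assay on cells (Cancer cell lines, Homo sapiens) for inhibition (on this read-out higher numbers stand for weaker inhibition of growth and lower numbers for stronger inhibition of growth), compound 1 gives 14100 nM. In this assay compound 2 gives 15500 nM. The two numbers lie within the scatter of each other, so neither compound can be set apart from the other on this read-out; compound 1 carries the lower of the two numbers, but the gap is within the usual scatter of repeated measurements.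

Compound 3 `Cc1cn2c(/C=N/NC(=N)N)c(-c3ccsc3)nc2s1` has not yet been measured. It differs from compound 1 in one place: thiophen-3-yl in place of 2,5-dimethylthiophen-3-yl on an aromatic carbon. The rest of the shared core and the hydrazone side chain are kept unchanged.

For the measured compounds named here, no step between measured compounds that differ in one place is available, so there is nothing to show how this change tends to move the read-out. The expectation for the step from compound 1 to compound 3 is therefore a small change, a 1.3-fold higher number from compound 1 to compound 3 (0.11 log units; within the scatter), not beyond the scatter in either direction. For compound 3 the estimate in this assay is 18000 nM, with a range from 6000 nM to 55000 nM.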

Compound 3, concentration for 50% growth inhibition: 10200 nM
Compound 3: middle estimate off by 1.8-fold (0.25 log units), on the high side; the measured number falls inside the stated range.
By their numbers in this assay, from the lowest: compounds 3, 1 and 2 (each within the scatter of the next).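

In this assay, among the compounds shown here, thiophen-3-yl in place of 2,5-dimethylthiophen-3-yl on an aromatic carbon gives a 1.4-fold lower number from compound 1 to compound 3 (0.14 log units; within the scatter), the first step that can be read at this position. Within this one pair, the read-out does not set the two thiophene groups apart, so the dimethyl substitution shows no effect beyond the scatter, and both compounds remain in the same range of growth inhibition. No measurement is available that would explain this outcome.

For the compounds shown here, the single step covers only two closely related thiophene groups, so it remains open how the read-out would respond at this position to a group of another kind, such as an amine or a carboxylic acid, or to a longer chain. From the compounds shown here alone, it also remains open how changes to the hydrazone side chain would act on their own, with the thiophen-3-yl group and the rest of the shared core held fixed, as compound 2 differs from compound 1 and compound 3 in more than one place.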